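This account rests on a few compounds, and the source may have more. Where it says the series, first, only, none or still open, it means among the compounds named here.

Measured so far in a toxicity assay on Vero cells (Chlorocebus sabaeus) for cytotoxicity; on this read-out higher numbers stand for lower toxicity in this test and lower numbers for higher toxicity in this test:
- compound 1 `COc1nc(-c2ccc(Br)cc2)ccc1[C@@H](c1ccccc1)[C@@](O)(CCN(C)C)c1cccc2ccccc12` gives > 50 ug/mL
- compound 2 `COc1ncc(-c2ccccc2)cc1[C@@H](c1ccccc1)[C@@](O)(CCN(C)C)c1cccc2ccccc12` gives > 50 ug/mL

Compound 1 sits at a limit of the test rather than at a measured number. Compound 2 likewise sits at a limit and not at a number. So the two values do not place compound 1 above or below any other compound; both simply show that no toxicity was reached within the tested range, and the limit of > 50 ug/mL in this assay, at which 2 of the 2 values shown sit, summarises where the two values stand. Compound 3 `COc1nc(-c2ccc(Cl)c(F)c2)ccc1[C@@H](c1ccccc1)[C@@](O)(CCN(C)C)c1cccc2ccccc12` has not been tested yet. It differs from compound 1 by 4-chloro-3-fluorophenyl in place of 4-bromophenyl on an aromatic carbon. For the measured compounds named here, no step between two measured compounds is available to say how an exchange of this kind moves the read-out, and since compound 1 itself has only a limit, any estimate rests on that limit alone. Compound 3 is expected to give about 60 ug/mL, within 25 ug/mL to 130 ug/mL. The step that the limit leaves unreadable from compound 1 to compound 3 is therefore expected to stay within the usual scatter, with no shift in either direction, and most likely the test will again report only a limit.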

Compound 3, half-maximal cytotoxic concentration: > 50 ug/mL
Compound 3: only a limit was reported; the forecaster's own chance of this, stated with the estimate: 80%; the middle value lies beyond the limit too.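

The exchange between compound 1 and compound 3 cannot be read as a step in this assay, because both sit at a limit and not at a number: the limit of > 50 ug/mL in this assay, at which 3 of the 3 values shown sit.

The compounds shown leave open at what concentration, if any, each becomes toxic to these cells, and whether 4-chloro-3-fluorophenyl in place of 4-bromophenyl alters that concentration.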